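Compound 4: a fluorophenyl group in place of trifluoromethylphenyl

The compounds below may be only part of what the source reports. "The series", "measured", "known", "first", "only" and "open" are said of these compounds alone.

In a physicochemical assay for solubility, using the shake flask method, in simulated intestinal fluid, measured as kinetic solubility, with a stated time of 2 h, at 25 degrees C, at pH 6.5 (a higher number here means a more soluble compound, a lower number a less soluble compound), compound 1 `Cc1noc(-c2nc(C)c3c(c2N)C(=O)N(CC2CCOCC2)C3=O)n1` gives 5700 nM. Compound 2 `Cc1noc(-c2nc(C)c3c(c2N)C(=O)N(Cc2ccc(Cl)cc2)C3=O)n1` gives < 5000 nM, which is a limit of the assay and not a number. Compound 3 `Cc1noc(-c2nc(C)c3c(c2N)C(=O)N(Cc2ccc(C(F)(F)F)cc2)C3=O)n1` gives < 5000 nM, which is also only a limit. Compound 3 therefore has no exact number and stands at the limit of < 5000 nM in this assay, at which 2 of the 3 values shown sit.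

Compound 4 `Cc1noc(-c2nc(C)c3c(c2N)C(=O)N(Cc2cccc(F)c2)C3=O)n1` changes one group of compound 3: 3-fluorophenyl in place of 4-(trifluoromethyl)phenyl on a saturated chain carbon bound to an amide-type nitrogen in a ring. Here 3-fluorophenyl takes the place of 4-(trifluoromethyl)phenyl on a saturated chain carbon bound to an amide-type nitrogen in a ring.

Two measured steps come closest, since each puts a substituted phenyl group at this place: an at least 1.1-fold lower number from compound 1 to compound 2 (0.05 log units; that floor lies within the scatter) and an at least 1.1-fold lower number from compound 1 to compound 3 (0.05 log units; that floor lies within the scatter). The step that the two limits leave unreadable from compound 2 to compound 3 offers no size to work from. With no measured step beyond the scatter to build on, no clear change is expected in this assay. The expected step is a step that the limit leaves unreadable from compound 3 to compound 4. For compound 4 the estimated value is 4000 nM, with an expected range from 1500 nM to 8000 nM.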

Compound 4, solubility: < 5000 nM
Compound 4 was reported as a limit; the forecaster's own chance of this, stated with the estimate: 70%; the middle value is on the limit's open side.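

Compound 4 shows that 3-fluorophenyl, in place of 4-(trifluoromethyl)phenyl, still gives only a limit and no exact number, as the other two substituted phenyl groups at this place do: the limit of < 5000 nM in this assay, at which 3 of the 4 values shown sit. Set against the oxan-4-yl group, this change gives an at least 1.1-fold lower number from compound 1 to compound 4 (0.05 log units; that floor lies within the scatter). The steps among the three compounds with a substituted phenyl group cannot be read.

The compounds shown leave open how far apart these three compounds truly lie, and whether any of them differs from compound 1 beyond the scatter. Also open, going by these compounds, is whether an amine or a carboxylic acid on the phenyl ring at this place would give an exact value in this assay.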